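The source may hold more compounds than are shown below. What is called first, only, known or untested is meant among the compounds shown, and "the series" means these compounds.

Going by the values given here, in a functional assay on HepG2 cells (Homo sapiens) for cytotoxicity, with a stated time of 24 h (a higher number here means a weaker inhibitor, a lower number a stronger inhibitor), compound 1 (`COc1cc(Cl)ccc1C(=S)Nc1cc(Cl)ccc1O`) gives 8490 nM, the higher of the two numbers measured so far. Among the compounds with values here, the only other measured compound, compound 2 (`COc1cc(Cl)ccc1C(=S)Nc1cc(Cl)c(Cl)cc1O`), gives 3160 nM. Compound 3 (`COc1cc(Cl)ccc1C(=S)Nc1cc(Br)ccc1O`) awaits measurement. It differs from compound 1 by a single swap, (bromo in place of chloro on an aromatic carbon), with bromo in place of chloro on an aromatic carbon, para to a hydroxy group. Within the data shown here, only one measured step bears on this: a 2.7-fold lower number from compound 1 to compound 2 (0.43 log units; beyond the scatter), a modest change beyond the scatter, made by putting chloro in place of hydrogen at another carbon. That step adds an atom to the ring, whereas the new swap only exchanges one for another, so a smaller shift towards a lower number is expected. The expected step is a 1.3-fold lower number from compound 1 to compound 3 (0.12 log units; within the scatter), which would lie within the scatter. For compound 3 the estimated value is 6500 nM, with an expected range of 3000 nM to 13000 nM.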

Compound 3, half-maximal inhibitory concentration: 6530 nM
Compound 3: middle estimate off by 1.0-fold (0.00 log units), on the low side, within the range that was stated.
By their numbers in this assay, from the lowest: compound 2; then compounds 3 and 1 (each within the scatter of the next).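

In this assay, placing bromo instead of chloro on the aromatic carbon para to a hydroxy group gives a 1.3-fold lower number from compound 1 to compound 3 (0.11 log units; within the scatter), so this assay does not separate these two halogens at this position. The earlier pair spoke only to another carbon, where adding chloro in place of hydrogen gave a 2.7-fold lower number from compound 1 to compound 2 (0.43 log units; beyond the scatter). Going by these compounds alone, this new step is the first reading at the position that carries the halogen in compound 1, and it shows that this exchange leaves the number within the scatter.

Only chloro and bromo are shown at this carbon, so it remains open whether a different kind of group, such as an amine or a carboxylic acid, would be tolerated as well. No measurement shown here offers an explanation for this result.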